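Ring-closed amine variant of a tryptamine 5-HT1D agonist

A few compounds are considered here, and "the series" means these few. Any claim that something is new, unique, unknown or untested is made for them only; others in the source may bear on it.

Measured compounds:
compound 1 `CN(CC(C)(C)C)CC1(O)CCN(CCCc2c[nH]c3ccc(-n4cnnc4)cc23)CC1` 1.6 nM
compound 2 `CN(Cc1ccccc1)CC1(O)CCN(CCCc2c[nH]c3ccc(-n4cnnc4)cc23)CC1` 3.8 nM

In a functional assay on CHO cells for agonist activity at 5-hydroxytryptamine receptor 1D (Homo sapiens), read by GTPgammaS binding (on this read-out higher numbers stand for an effect only at larger amounts of compound and lower numbers for an effect already at smaller amounts), compound 1 gives the lowest of the two numbers; its nearest neighbour is compound 2, and the step from compound 1 to compound 2, a 2.4-fold higher number from compound 1 to compound 2 (0.38 log units; beyond the scatter), is modest but beyond the scatter. Compound 3 `CC1(C)CCCN(CC2(O)CCN(CCCc3c[nH]c4ccc(-n5cnnc5)cc34)CC2)C1` has not been measured. It differs from compound 1 by 3,3-dimethylpiperidin-1-yl in place of methyl(neopentyl)amino on a saturated chain carbon bound to a saturated ring carbon. Among the compounds with values here, no measured pair shows the same kind of change: the only step available, a 2.4-fold higher number from compound 1 to compound 2 (0.38 log units; beyond the scatter), swaps one terminal group for another on the open chain of the amine, whereas compound 3 keeps the two methyl groups and closes the amine into a ring. That step shows only a modest shift in this assay, so compound 3 is expected to stay near compound 1, with at most a small upward step, a 1.6-fold higher number from compound 1 to compound 3 (0.19 log units; within the scatter). The estimate for compound 3 is 2.5 nM, within 0.8 nM to 8 nM.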

Compound 3, concentration for half-maximal effect: 0.9 nM
For compound 3 the middle estimate is 2.8-fold (0.44 log units) above the measured one; the range from low to high includes it.
By their numbers in this assay, from the lowest: compounds 3 and 1 (each within the scatter of the next); then compound 2.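

In this assay, the ring-closed 3,3-dimethylpiperidin-1-yl group and the open methyl(neopentyl)amino group on this saturated chain carbon cannot be told apart, with a 1.8-fold lower number from compound 1 to compound 3 (0.25 log units; within the scatter) as the step between them. Against the benzyl(methyl)amino group the same ring does separate, with a 4.2-fold lower number from compound 2 to compound 3 (0.63 log units; beyond the scatter) as the step, so this position accepts an amine closed into a ring, something the two open-chain compounds could not show. Nothing available here explains either step.

The compounds shown leave open whether the two methyl groups on the ring matter, as a plain piperidin-1-yl group would test. They also leave open whether a different ring on the same carbon, such as pyrrolidin-1-yl or morpholin-4-yl, would give a number close to those of compound 1 and compound 3.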